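Pyridine to pyrimidine on a cytotoxicity-silent anilide

The source may hold more compounds than are shown below. What is called first, only, known or untested is meant among the compounds shown, and "the series" means these compounds.

Compound 1 `Cc1ccc(C(=O)Nc2cc(-c3cnn(C)c3)cc(C(F)(F)F)c2)cc1Nc1cc(-c2cccnc2)ccn1` is tested in a toxicity assay on H9c2 cells (Rattus norvegicus) for cytotoxicity, read by MTT assay, with a stated time of 48 h (a lower number here means a stronger inhibitor, a higher number a weaker inhibitor), and, in this assay, compound 1 gives only a limit of > 80000 nM. Compound 2 `Cc1cn(-c2cc(NC(=O)c3ccc(C)c(Nc4cc(-c5cccnc5)ccn4)c3)cc(C(F)(F)F)c2)cn1` likewise gives only a limit of > 80000 nM in this assay. Compound 3 `Cc1ccc(C(=O)Nc2ccc(CN3CCN(C)CC3)c(C(F)(F)F)c2)cc1Nc1cc(-c2cccnc2)ccn1`, which carries a different substituent pattern on the anilide ring, gives 9120 nM in this assay. For the measured compounds named here, the one step between compounds differing in a single place, a step that the two limits leave unreadable from compound 1 to compound 2, cannot be read in size because the limit of > 80000 nM in this assay, at which 2 of the 3 values shown sit, holds both of its ends.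

Compound 4 `Cc1ccc(C(=O)Nc2cc(-c3cnn(C)c3)cc(C(F)(F)F)c2)cc1Nc1cc(-c2cncnc2)ccn1` differs from compound 1 by pyrimidin-5-yl in place of pyridin-3-yl on an aromatic carbon. Going by the values given here, no measured step touches this ring of the shared core, so the only guidance is that compound 1 and compound 2, which differ elsewhere, both sit at the limit. On that basis the step from compound 1 to compound 4 in this assay is expected to be none beyond the scatter, a step that the limit leaves unreadable from compound 1 to compound 4, with compound 4 most probably again reported only as a limit. Compound 4 is therefore estimated at 100000 nM, within a range from 40000 nM to 250000 nM, in this assay.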

Compound 4, half-maximal inhibitory concentration: > 80000 nM
Compound 4: a limit, no number (the forecaster's own chance of this, stated with the estimate: 75%); the middle value lies beyond the limit too.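

In this assay compound 4 gives > 80000 nM, which is a limit and not a number. No step from compound 1 to compound 4 can be read, because both compounds sit at the same limit: the limit of > 80000 nM in this assay, at which 3 of the 4 values shown sit.

The compounds shown leave open whether pyrimidin-5-yl in place of pyridin-3-yl changes this cytotoxicity read-out at all.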